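A drawn configuration dropped from a fluoro-indazole analogue

The source may report more compounds than this note shows. Statements on the series, on what has been measured and on what is new or still open speak of the compounds shown alone.

Compounds measured in a functional assay on CHO cells for agonist activity at Melanocyte-stimulating hormone receptor (Homo sapiens), read by a luciferase reporter, with a stated time of 4 h; a higher number here means that more compound is needed for the effect, a lower number that less compound is needed:
compound 1 `COc1ccc(N(C(=O)CN2C=CN(c3ccccc3)C(=O)C(Cc3n[nH]c4ccccc34)C2=O)C(C)C)cc1` gives 29.5 nM
compound 2 `CC(C)N(C(=O)CN1C=CN(c2ccccc2)C(=O)[C@H](Cc2n[nH]c3ccccc23)C1=O)c1ccccc1` gives 295 nM
compound 3 `CC(C)N(C(=O)CN1C=CN(c2ccccc2)C(=O)[C@H](Cc2n[nH]c3cc(F)ccc23)C1=O)c1ccccc1` gives 35.5 nM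

Compound 3 stands second highest of the three numbers in this assay. Its nearest neighbour is compound 1, whose value lies within the scatter of that of compound 3, so the two cannot be ordered. The furthest is compound 2, and the single step shown, an 8.3-fold lower number from compound 2 to compound 3 (0.92 log units; beyond the scatter), is beyond the scatter.

Compound 4 `CC(C)N(C(=O)CN1C=CN(c2ccccc2)C(=O)C(Cc2n[nH]c3cc(F)ccc23)C1=O)c1ccccc1` is the next member. Against compound 3 the change is the two compounds have the same atoms and bonds; at least one stereo element is drawn with a configuration in one of them and without one in the other: 1 of 1 stereo elements differ; a stereocentre at a saturated ring carbon is drawn R in compound 3 and without a configuration in compound 4: the two compounds have the same atoms and bonds, and the stereocentre at a saturated ring carbon is drawn R in compound 3 and without a configuration in compound 4. For the measured compounds named here, no measured step bears on this change. Compound 1 is also drawn without a configuration, and its value sits within the scatter of that of compound 3, which is the only hint available. Compound 4 is therefore expected to lie close to compound 3, with the step of a 1.5-fold higher number from compound 3 to compound 4 (0.19 log units; within the scatter) estimated as small and towards a higher number. The estimate for compound 4 in this assay is 55 nM, within 22 nM to 160 nM.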

Compound 4, half-maximal effective concentration: 186 nM
Beside the measured number, compound 4's estimate is 3.4-fold (0.53 log units) below it; the whole stated range lies below it.
By their numbers in this assay, from the lowest: compounds 1 and 3 (each within the scatter of the next); then compounds 4 and 2 (each within the scatter of the next).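

Until this point the only listed step had concerned the fluoro on the aromatic carbon, and the stereocentre at the saturated ring carbon had not been tested on its own. In this assay, the pair of compound 3 and compound 4 isolates that stereocentre, and removing the drawn R configuration gives a 5.2-fold higher number from compound 3 to compound 4 (0.72 log units; beyond the scatter), so how this position is defined is not a neutral detail of the drawing in the fluoro series. With the same atoms and bonds in both compounds, no substituent can account for this step, and the only recorded difference between them is: the fact that one of compounds 3 and 4 is drawn with a defined configuration and the other without, at the place where they differ

The drawing of compound 4 does not say which configurations the sample holds or in what proportion, and a counterpart drawn S is absent from the compounds shown, so the value of the opposite configuration remains unknown. Also open, as far as these compounds go, is whether the same gap between a drawn and an undrawn stereocentre would appear with a chloro or a nitrile on that aromatic carbon in place of the fluoro.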